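The source may hold more compounds than are shown below. What is called first, only, known or untested is meant among the compounds shown, and "the series" means these compounds.

Compound 1 `N#Cc1ccc(Cn2cc(/C=C3\NC(=O)NC3=O)c3ccccc32)cc1` — in a functional assay on A549 cells (Homo sapiens) for antiproliferative activity, read by trypan blue exclusion, with a stated time of 24 h (on this read-out higher numbers stand for weaker inhibition and lower numbers for stronger inhibition), compound 1 gives > 40000 nM, which is a limit of the assay and not a number.
Compound 2 `O=C1NC(=O)/C(=C/c2cn(Cc3ccc([N+](=O)[O-])cc3)c3ccccc23)N1` — compound 2 gives > 40000 nM, again a limit rather than a number.
Compound 3 `O=C1NC(=O)/C(=C/c2cn(Cc3ccc(Cl)cc3)c3ccccc23)N1` — compound 3 gives 25400 nM.

Among the compounds with values here, compound 3 therefore stands as the only compound of the three with an actual number; the other two sit at the limit of > 40000 nM in this assay, at which 2 of the 3 values shown sit. The measured steps all concern the group on the phenyl ring of the benzyl arm: an at least 1.5-fold lower number from compound 1 to compound 3 (0.19 log units; that floor lies within the scatter), an at least 1.5-fold lower number from compound 2 to compound 3 (0.19 log units; that floor lies within the scatter), and a step that the two limits leave unreadable from compound 1 to compound 2.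

Compound 4 `O=C1NC(=O)/C(=C/c2cn(Cc3ccccc3Br)c3ccccc23)N1` differs from compound 3 by 2-bromophenyl in place of 4-chlorophenyl on a saturated chain carbon bound to an aromatic nitrogen. Within the data shown here, no measured step repeats this change: each of the three steps exchanged one group for another on the phenyl ring, but none exchanged chloro for bromo or led to a 2-bromophenyl. There is thus no measured basis for expecting a step in either direction, and the number for compound 4 is expected to sit near that of compound 3, with a 1.1-fold higher number from compound 3 to compound 4 (0.04 log units; within the scatter) as the estimated step. For compound 4 the estimate is 28000 nM, within a range from 9000 nM to 60000 nM.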

Compound 4, half-maximal inhibitory concentration: 39500 nM
For compound 4 the middle estimate is 1.4-fold (0.15 log units) below the measured one; low and high end bracket the measured number.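

With two actual numbers to compare in this assay, exchanging 4-chlorophenyl for 2-bromophenyl on the saturated chain carbon gives a 1.6-fold higher number from compound 3 to compound 4 (0.19 log units; within the scatter), so this change of halogen and of its place on the phenyl ring shifts the result by no more than repeat measurements would. Set against the other two compounds, compound 4 gives only floors that show no readable difference: an at least 1.0-fold lower number from compound 2 to compound 4 (0.00 log units; that floor lies within the scatter), and an at least 1.0-fold lower number from compound 1 to compound 4 (0.00 log units; that floor lies within the scatter). Compound 1 and compound 2 still have no number, only a limit: the limit of > 40000 nM in this assay, at which 2 of the 4 values shown sit.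

The halogen and its place on the ring differ together in this single step, so the compounds shown cannot separate the two. As far as these compounds go, it also stays open whether an amine or a carboxylic acid on the phenyl ring, or a longer chain to it, would move the number clearly.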